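A few compounds are considered here, and "the series" means these few. Any claim that something is new, unique, unknown or untested is made for them only; others in the source may bear on it.

Series notes. Compound 1 `CCCNCc1cc(-c2c(C(=O)NCC)noc2-c2cc(C(C)C)c(O)cc2O)on1` in a functional assay on A2780 cells (Homo sapiens) for inhibition (on this read-out higher numbers stand for weaker inhibition and lower numbers for stronger inhibition), carries the entry "not determined" (no result reported); compound 2 `CCNC(=O)c1noc(-c2cc(C(C)C)c(O)cc2O)c1-c1cc(CNCCO)no1` in this assay likewise carries the entry "not determined" (no result reported). Within the data shown here, the only measured member is compound 3 `CCNC(=O)c1noc(-c2cc(C(C)C)c(O)cc2O)c1-c1cc(CN(CC)CC)no1`, which in this assay gives 78 nM. Among the measured compounds shown here, no step between measured compounds is available, so compound 1 stands without a number of its own and without a measured neighbour. Compound 4 `CCNC(=O)c1noc(-c2cc(C(C)C)c(O)cc2O)c1-c1cc(C(=O)NC)no1` differs from compound 1 by a single change: methylcarbamoyl in place of (propylamino)methyl on an aromatic carbon. For the measured compounds named here, with no measured pair to anchor the step, its direction and size in this assay are open; a change of roughly the usual scatter in either direction is expected, with no firm lean. Compound 4 is estimated at 150 nM, with a range from 30 nM to 800 nM, taking compound 3 at 78 nM as the only point of reference.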

Compound 4, half-maximal inhibitory concentration: 100 nM
Compound 4: middle estimate off by 1.5-fold (0.18 log units), on the high side; the range from low to high includes it.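

In this assay, among these compounds, the first readable pair at this position gives a 1.3-fold higher number from compound 3 to compound 4 (0.11 log units; within the scatter). On this aromatic carbon, next to the ring nitrogen, methylcarbamoyl and (diethylamino)methyl therefore read alike, so a carbonyl-bearing group and an amine-bearing group are both compatible here in these two compounds. Nothing at hand accounts for this result.

Steps involving compound 1 and compound 2 cannot be read. Still open, going by these compounds, is how a carboxylic acid or a longer amide chain at this position would read.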